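The source may report more compounds than this note shows. Statements on the series, on what has been measured and on what is new or still open speak of the compounds shown alone.

Measured so far in a functional assay on A549 cells (Homo sapiens) for cytotoxicity, read by MTT assay, with a stated time of 72 h; a higher number here means a weaker inhibitor, a lower number a stronger inhibitor:
compound 1 `CN1CCN(CCCCCn2c3c(c4ccccc42)C(=O)c2c[n+]([O-])c4ccccc4c2C3=O)CC1`, 870 nM
compound 2 `CN(C)CCCCn1c2c(c3ccccc31)C(=O)c1c[n+]([O-])c3ccccc3c1C2=O`, 310 nM

Compound 2 stands lowest of the two, its nearest neighbour being compound 1 at a 2.8-fold lower number from compound 1 to compound 2 (0.45 log units; beyond the scatter). Compound 3 `CCCCN1CCN(CCCCn2c3c(c4ccccc42)C(=O)c2c[n+]([O-])c4ccccc4c2C3=O)CC1` is not yet measured. It differs from compound 2 by 4-butylpiperazin-1-yl in place of dimethylamino on a saturated chain carbon, four bonds along the chain from an aromatic nitrogen. Going by the values given here, the only step that bears on this is the one from compound 1 to compound 2, a modest change, and compound 3 reverses its sense by bringing a piperazine back. A modest rise is therefore expected, a 2.3-fold higher number from compound 2 to compound 3 (0.35 log units; beyond the scatter). Compound 3 is estimated at 700 nM, expected between 300 nM and 1600 nM.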

Compound 3, half-maximal inhibitory concentration: 550 nM
The estimate for compound 3 lay 1.3-fold (0.10 log units) above the measured number; low and high end bracket the measured number.
By their numbers in this assay, from the lowest: compounds 2, 3 and 1 (each within the scatter of the next, the first and the last beyond it).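

At this saturated chain carbon, four bonds along the chain from an aromatic nitrogen, 4-butylpiperazin-1-yl with 10 heavy atoms and dimethylamino with 3 are not separated in this assay (a 1.8-fold higher number from compound 2 to compound 3 (0.25 log units; within the scatter)). Compound 3 is not separated from the other piperazine either (a 1.6-fold lower number from compound 1 to compound 3 (0.20 log units; within the scatter)), so the presence of a piperazine at this place does not by itself reproduce the gap printed for the earlier step. No evidence on the origin of these numbers is at hand.

Going by these compounds, whether a morpholine, a primary amine or a carboxylic acid at this place would read apart from these compounds remains open.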